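Hydroxy removal on the core of compound 1

The source may hold more compounds than are shown below. What is called first, only, known or untested is meant among the compounds shown, and "the series" means these compounds.

Compound 1 `CC/C=C(\C)[C@H]1OC(=O)[C@H](C)N(C)C(=O)[C@H](C(C)C)NC(=O)CN(C)C(=O)[C@@H](CC(C)C)N(C)C(=O)[C@H](C(C)C)NC(=O)[C@@H]([C@@H](C)CC)OC(=O)/C(C)=C/C[C@H](O)[C@@H]1C` is the reference here. Among the compounds with values here, in a functional assay on HeLa cells (Homo sapiens) for cytotoxicity (a lower number here means a stronger inhibitor, a higher number a weaker inhibitor), compound 1 gives 0.0024 ug/mL, the only number in the set. Compound 2 `CC/C=C(\C)[C@H]1OC(=O)[C@H](C)N(C)C(=O)[C@@H](C(C)C)NC(=O)CN(C)C(=O)[C@@H](CC(C)C)N(C)C(=O)[C@H](C(C)C)NC(=O)[C@@H]([C@@H](C)CC)OC(=O)/C(C)=C/C[C@H](O)[C@@H]1C` is its stereoisomer. In this assay compound 2 reaches only a limit, > 4 ug/mL. Within the data shown here, the one measured step, an at least 1600-fold higher number from compound 1 to compound 2 (3.22 log units; beyond the scatter), rests on the fact that compounds 1 and 2 differ only in the configuration as drawn and (the limit of > 4 ug/mL in this assay, at which 1 of the 2 values shown sits).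

Compound 3 `CC/C=C(\C)[C@H]1OC(=O)[C@H](C)N(C)C(=O)[C@H](C(C)C)NC(=O)CN(C)C(=O)[C@@H](CC(C)C)N(C)C(=O)[C@H](C(C)C)NC(=O)[C@@H]([C@@H](C)CC)OC(=O)/C(C)=C/CC[C@@H]1C` is not yet measured. It differs from compound 1 by hydrogen in place of hydroxy on a saturated ring carbon. Among the measured compounds shown here, the measured step from compound 1 to compound 2 is a change of configuration alone and does not bear on the loss of a hydroxy; no step between measured compounds tests this change. With no guidance on it, a moderate weakening is expected as the working assumption, and the estimated step is an 8.3-fold higher number from compound 1 to compound 3 (0.92 log units; beyond the scatter). In this assay compound 3 is thus expected to give about 0.02 ug/mL, within 0.003 ug/mL to 0.2 ug/mL.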

Compound 3, half-maximal inhibitory concentration: 0.017 ug/mL
Compound 3: middle estimate off by 1.2-fold (0.07 log units), on the high side, and the stated range covers the measured number.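

In this assay, within the data shown here, removing the hydroxy from this saturated ring carbon gives a 7.1-fold higher number from compound 1 to compound 3 (0.85 log units; beyond the scatter), so the position has now been tested directly for the first time. The hydroxy adds to potency but is not required for it: compound 3 gives a measured 0.017 ug/mL, and this loss is far smaller than the change of configuration alone, an at least 1600-fold higher number from compound 1 to compound 2 (3.22 log units; beyond the scatter). The data at hand give no cause for the step from hydroxy to hydrogen.

Open, on these data alone, is whether another group can replace the hydroxy at this carbon, for instance a methoxy, an acetoxy or an amine, and whether any of these would match compound 1 or fall further toward compound 3. Also open, as far as these compounds go, is how the opposite configuration of the hydroxy-bearing carbon would read.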